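Iodo for Bromo: Estimating the Cytotoxicity of Compound 4

The source may hold more compounds than are shown below. What is called first, only, known or untested is meant among the compounds shown, and "the series" means these compounds.

Measured compounds:
compound 1 `CCC[C@@H](OC(C)=O)C1=C(Br)/C(=C/Br)OC1=O` gives 1 ug/mL
compound 2 `CCCCC1=C(Br)/C(=C/Br)OC1=O` gives > 20 ug/mL, a limit of the assay
compound 3 `CCC[C@@H](O)C1=C(Br)/C(=C/Br)OC1=O` gives 0.1 ug/mL

In a functional assay on KB cells (Homo sapiens) for cytotoxicity (on this read-out higher numbers stand for an effect only at larger amounts of compound and lower numbers for an effect already at smaller amounts), compound 1 stands at the higher of the two numbers that were obtained. Compound 3 sits at a 10-fold lower number from compound 1 to compound 3 (1.00 log units; beyond the scatter). Compound 2 reaches only (the limit of > 20 ug/mL in this assay, at which 1 of the 3 values shown sits), so its value is a limit and not a number. The two remaining steps are an at least 20-fold higher number from compound 1 to compound 2 (1.30 log units; beyond the scatter) and an at least 200-fold lower number from compound 2 to compound 3 (2.30 log units; beyond the scatter).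

The new compound 4 `CCC[C@@H](OC(C)=O)C1=C(Br)/C(=C/I)OC1=O` differs from compound 1 by iodo in place of bromo on a double-bonded chain carbon bound to a double-bonded ring carbon. Going by the values given here, none of the measured steps concerns this halogen: all three alter the substituent on the saturated chain carbon bound to a double-bonded ring carbon, where the acetoxy and hydroxy groups gave the large and modest steps just named, while the halogenated part of the core stayed untouched. Among the compounds with values here, there is therefore no direct precedent for the exchange of one halogen for another at this site, and the expectation rests on the absence of any change in the groups that did move the numbers.

Compound 4 is accordingly expected to show no change at the digits printed from compound 1 to compound 4 (within the scatter), a step not beyond the scatter. The estimate for compound 4 is 1 ug/mL, with a range from 0.3 ug/mL to 4 ug/mL.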

Compound 4, concentration for half-maximal effect: 0.2 ug/mL
For compound 4 the middle estimate is 5.0-fold (0.70 log units) above the measured one, outside the stated range (below it).
By their numbers in this assay, from the lowest: compounds 3 and 4 (each within the scatter of the next); then compound 1. At a limit, above all of these: compound 2.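

In this assay, the halogen on the double-bonded chain carbon proves able to move the read-out: iodo in place of bromo gives a 5.0-fold lower number from compound 1 to compound 4 (0.70 log units; beyond the scatter). Going by these compounds alone, the earlier steps all changed the substituent on the saturated chain carbon and left this halogen untouched, so this is the first sign that the read-out also responds to a change at this place, even though one heavy atom simply replaces another and no hydrogen-bond donor or acceptor enters or leaves. Nothing in the data shown bears on why the exchange of bromo for iodo has this effect.

Whether the same exchange would carry over to other substituents on the saturated chain carbon stays open, since the iodo group is shown only with the acetoxy group of compound 4 and not with the hydroxy group of compound 3, which gives 0.1 ug/mL. Also open, as far as these compounds go, is how a chloro, a nitrile or a methyl group on the same double-bonded chain carbon would compare with bromo and iodo.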